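Swapping a Fluorophenyl Amide for a Chloropyridinyl Amide

The source may report more compounds than this note shows. Statements on the series, on what has been measured and on what is new or still open speak of the compounds shown alone.

Compound 3 `O=C(Nc1cccc(-c2oc3cc(-c4ccc(F)cc4)ccc3c(=O)c2O)c1)c1cccc(F)c1` gives the lowest number of the three in a functional assay on MCF7 cells (Homo sapiens) for antiproliferative activity, read by CCK-8 assay, with a stated time of 72 h (a lower number here means a stronger inhibitor, a higher number a weaker inhibitor), at 5770 nM. Compound 1 `O=C(Nc1cccc(-c2oc3cc(-c4ccc(F)cc4)ccc3c(=O)c2O)c1)c1ccccc1F` gives 7570 nM, and the step of a 1.3-fold lower number from compound 1 to compound 3 (0.12 log units; within the scatter) lies within the scatter, so these two cannot be ranked against each other. Compound 2 `O=C(Nc1cccc(-c2oc3cc(-c4ccc(F)cc4)ccc3c(=O)c2O)c1)c1ccc(Br)cc1` gives 24000 nM, and the step of a 4.2-fold lower number from compound 2 to compound 3 (0.62 log units; beyond the scatter) is a modest one. Compound 4 `O=C(Nc1cccc(-c2oc3cc(-c4ccc(F)cc4)ccc3c(=O)c2O)c1)c1ccc(Cl)nc1` differs from compound 3 by 6-chloropyridin-3-yl in place of 3-fluorophenyl on a carbonyl carbon. Among the compounds with values here, no measured step exchanges the carbon-only ring for one holding a nitrogen, so the only guide is that changing this ring has so far shifted numbers modestly at most. The number for compound 4 is therefore expected to move by a 1.4-fold higher number from compound 3 to compound 4 (0.14 log units; within the scatter), a slightly higher value being somewhat more likely. Compound 4 is estimated at 8000 nM, within a range from 3000 nM to 25000 nM.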

Compound 4, half-maximal inhibitory concentration: 2890 nM
The estimate for compound 4 lay 2.8-fold (0.44 log units) above the measured number, outside the stated range (below it).
By their numbers in this assay, from the lowest: compounds 4, 3 and 1 (each within the scatter of the next, the first and the last beyond it); then compound 2.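

In this assay the step of a 2.0-fold lower number from compound 3 to compound 4 (0.30 log units; within the scatter) stays within the scatter, so a ring holding a nitrogen and a chlorine serves on this carbonyl carbon as well as the 3-fluorophenyl ring does. Unlike compound 3, compound 4 stands clear of the 2-fluorophenyl amide, with a 2.6-fold lower number from compound 1 to compound 4 (0.42 log units; beyond the scatter) beyond the scatter, and an 8.3-fold lower number from compound 2 to compound 4 (0.92 log units; beyond the scatter) is the widest step at this position so far. Nothing measured here explains these shifts.

Compound 4 brings in the ring nitrogen and the chlorine together, leaving their separate contributions unknown. A plain pyridin-3-yl ring and a 4-chlorophenyl ring would pull the two apart.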